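The source may hold more compounds than are shown below. What is called first, only, known or untested is meant among the compounds shown, and "the series" means these compounds.

Notes on the series in an ADME assay on HCT-116 cells (Homo sapiens) for cytotoxicity, read by CellTiter-Glo, with a stated time of 72 h (on this read-out higher numbers stand for weaker inhibition and lower numbers for stronger inhibition), follow. Compound 1 `CCCOc1ccc(S(=O)(=O)N2CCC(N3CCC(C)CC3)CC2)cc1` reads > 5000 nM here, which is a limit and not a number. Compound 2 `CC1CCN(C2CCN(S(=O)(=O)c3ccc(-c4ccc(Cl)cc4)cc3)CC2)CC1` reads > 5000 nM in this assay and this too is a limit and not a number. Compound 2 therefore has no measured number, and the whole record so far is the limit of > 5000 nM in this assay, at which 2 of the 2 values shown sit, with nothing else beside it.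

The next compound is compound 3 `CC1CCN(C2CCN(S(=O)(=O)c3ccc(C(C)C)cc3)CC2)CC1` which has isopropyl in place of 4-chlorophenyl on an aromatic carbon, para to a large group (isopropyl in place of 4-chlorophenyl on an aromatic carbon). Among the compounds with values here, the one measured step that bears on this change is a step that the two limits leave unreadable from compound 1 to compound 2 and it also exchanges the group on that aromatic carbon, yet it offers no size to carry over. No step beyond the scatter is therefore expected in this assay in either direction, and a further limit is the likeliest reading. The expected change is a step that the limit leaves unreadable from compound 2 to compound 3 as an estimate only. The estimate for compound 3 is 7000 nM with an expected range from 3000 nM to 20000 nM if a number is reported at all.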

Compound 3, half-maximal inhibitory concentration: > 5000 nM
Compound 3 ended at the assay's limit; the forecaster's own chance of this, stated with the estimate: 85%; the middle value is on the limit's open side.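

In this assay compound 3 gives > 5000 nM, which is a limit and not a number. No step can be read among compound 1, compound 2 and compound 3, and the record stays at a single value: the limit of > 5000 nM in this assay, at which 3 of the 3 values shown sit.

The compounds shown leave open whether propoxy, 4-chlorophenyl and isopropyl differ at all in this assay.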